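A few compounds are considered here, and "the series" means these few. Any claim that something is new, unique, unknown or untested is made for them only; others in the source may bear on it.

Compound 1 `Nc1nc(O)c2ncn([C@H]3C[Se][C@@H](CO)O3)c2n1` and compound 2 `OC[C@H]1O[C@H](n2cnc3c(O)ncnc32)C[Se]1` share the same sugar-like ring joined to the shared core, and both were tested in a functional assay on Vero cells (Chlorocebus sabaeus) for cytotoxicity; a lower number here means a stronger inhibitor, a higher number a weaker inhibitor. For compound 1 the result in this assay is a limit of the assay, > 100000 nM, not a measured number. For compound 2 the result in this assay is likewise a limit, > 100000 nM, and not a number. For the measured compounds named here, compound 2 thus stands at the same limit as the only other value at hand, and the limit of > 100000 nM in this assay, at which 2 of the 2 values shown sit, shows that both measured results sit there. Compound 3 `Nc1nc(O)c2ncn([C@@H]3C[Se][C@@H](CO)O3)c2n1` is the compound still to be tested; it differs from compound 2 by amino in place of hydrogen on an aromatic carbon, which is amino in place of hydrogen on an aromatic carbon. Going by the values given here, no step between two measured compounds is available, so nothing anchors the size of this change; the expectation is that it gives no movement beyond the usual scatter and that compound 3 again reaches only the limit. The step from compound 2 to compound 3 in this assay is expected to be a number no higher from compound 2 to compound 3 (the limit leaves the size open). Compound 3 is estimated at 100000 nM in this assay, within 50000 nM to 300000 nM.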

Compound 3, half-maximal inhibitory concentration: > 100000 nM
Compound 3 was reported as a limit; the forecaster's own chance of this, stated with the estimate: 85%; the middle value sits exactly at the limit.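

In this assay compound 3 gives > 100000 nM, which is a limit and not a number. Compound 1 and compound 2 also stand at limits, so the steps to compound 3 cannot be read. The compounds shown leave open whether amino in place of hydrogen, or the difference in configuration, moves the result in this assay at all.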